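Removing a methoxy group from an inactive thiosemicarbazone

The compounds below may be only part of what the source reports. "The series", "measured", "known", "first", "only" and "open" are said of these compounds alone.

Measured compounds:
compound 1, `COc1ccc(C)cc1NC(=S)N/N=C/c1ccc2ccccc2n1`: > 100000 nM
compound 2, `CN(C)C(=S)N/N=C/c1ccc2cccnc2n1`: 560 nM

Of the compounds shown here, two have been tested in a functional assay on HL-60 cells (Homo sapiens) for antiproliferative activity, read by sulforhodamine B assay, with a stated time of 72 h; a lower number here means a stronger inhibitor, a higher number a weaker inhibitor. In this assay compound 1 gives > 100000 nM, which is a limit of the assay rather than a number; it sits at the limit of > 100000 nM in this assay, at which 1 of the 2 values shown sits. Compound 2, which has a different core, gives 560 nM in this assay, a measured number. Among the measured compounds shown here, no step connecting compound 1 and compound 2 is defined here, so these two values are simply reported side by side.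

The piece follows the step from compound 1 to compound 3, `Cc1cccc(NC(=S)N/N=C/c2ccc3ccccc3n2)c1`. The change is hydrogen in place of methoxy on an aromatic carbon. For the measured compounds named here, the methoxy group leaves the six-membered aromatic ring of carbon only that carries the methyl group, and nothing but a hydrogen atom takes its place.

Since compound 1 only reaches a limit, there is no firm number to move from. The step from compound 1 to compound 3 is expected to be a number no higher from compound 1 to compound 3 (the limit leaves the size open), with no change beyond the scatter assumed. Compound 3 is therefore estimated at 100000 nM in this assay, most likely between 20000 nM and 500000 nM.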

Compound 3, half-maximal inhibitory concentration: > 100000 nM
Compound 3 ended at the assay's limit; the forecaster's own chance of this, stated with the estimate: 70%; the middle value sits exactly at the limit.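

In this assay compound 3 gives > 100000 nM, a limit and not a number, so with compound 1 also at a limit, no step between the two can be read: the limit of > 100000 nM in this assay, at which 2 of the 3 values shown sit.

The compounds shown leave open whether hydrogen in place of methoxy on an aromatic carbon changes activity in this assay at all.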